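The source may hold more compounds than are shown below. What is called first, only, known or untested is meant among the compounds shown, and "the series" means these compounds.

Three close relatives of one shared core have been tested in a functional assay on PC-3 cells (Homo sapiens) for antiproliferative activity, read by MTT assay, with a stated time of 48 h; on this read-out higher numbers stand for weaker inhibition and lower numbers for stronger inhibition. Compound 1 `C#CCOc1ccc(/C=C/C(C)=O)cc1OC` gives 40200 nM in this assay. Compound 2 `COc1cc(/C=C/C(C)=O)ccc1OCc1cn(-c2ccc(/N=N/c3ccccc3)cc2)nn1` gives 42100 nM in this assay. Compound 3 `COc1cccc(-n2cc(COc3ccc(/C=C/C(C)=O)cc3OC)nn2)c1` gives 31600 nM in this assay, the lowest of the three numbers, yet its gaps to compound 1 and to compound 2 both lie within the usual scatter of repeated measurements, so the three compounds cannot be told apart on these numbers alone.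

Compound 4 `COc1cc(/C=C/C(C)=O)ccc1OCc1cn(-c2cc(F)cc(Br)c2)nn1` has not yet been measured in this assay. It differs from compound 3 in a single place: 3-bromo-5-fluorophenyl in place of 3-methoxyphenyl on an aromatic nitrogen. Going by the values given here, no measured pair in this set shows what such a change on the aromatic nitrogen does to the read-out, and the three measured values are so close together that no direction can be read from them. The reasonable expectation is that compound 4 stays in the same weak range as compound 3, because compound 3 gives 31600 nM and its neighbours scatter around the same level. The expected step is a 1.0-fold higher number from compound 3 to compound 4 (0.01 log units; within the scatter), with no clear direction and quite possibly none beyond the scatter. Compound 4 is therefore estimated at 32000 nM in this assay, with a range from 12000 nM to 80000 nM.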

Compound 4, half-maximal inhibitory concentration: 56900 nM
Estimate against measurement, compound 4: 1.8-fold (0.25 log units) below; the range from low to high includes it.
By their numbers in this assay, from the lowest: compounds 3, 1, 2 and 4 (each within the scatter of the next).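

In this assay, going by these compounds alone, putting 3-bromo-5-fluorophenyl in place of 3-methoxyphenyl on the aromatic nitrogen gives a 1.8-fold higher number from compound 3 to compound 4 (0.26 log units; within the scatter) and is the first single-place change measured at this position. The entering group has the same count of heavy atoms as the leaving one, yet it carries fluorine and bromine instead of oxygen and has no hydrogen-bond acceptor, and even so the read-out does not move beyond the usual scatter. This one pair therefore shows that this particular exchange leaves the antiproliferative read-out unresolved, while no separate measurement bears on why.

Bromine and fluorine enter together here, so what each does alone stays open, as does whether a phenyl ring on this nitrogen matters at all. A ring carrying an amine or a carboxylic acid, or a simple longer alkyl chain directly on the nitrogen, would test whether the read-out at this position can move clearly out of its present range.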